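Ester in Place of Hexyl on a Triazole-Bearing Quinoline Scaffold

This account rests on a few compounds, and the source may have more. Where it says the series, first, only, none or still open, it means among the compounds named here.

Measured compounds:
Compound 1 `COc1nc2ccc(Br)cc2cc1C(c1ccccc1)n1cc(-c2ccc(Br)cc2)nn1`: 7.43%
Compound 2 `CCCCCCc1cn(C(c2ccccc2)c2cc3cc(Br)ccc3nc2OC)nn1`: 2.32%
Compound 3 `COc1nc2ccc(Br)cc2cc1C(c1ccccc1)n1cc(-c2ccccc2F)nn1`: 13.4%

Of the compounds shown here, three have been measured in an ADME assay on PC-3 cells (Homo sapiens) for cytotoxicity, read by sulforhodamine B assay, with a stated time of 48 h, tested at 10 uM; a lower number here means less inhibition, a higher number more inhibition at the concentration tested (going by the name of the read-out). Going by the values given here, compound 2 gives the lowest of the three numbers, but the step of a number 5.1 percentage points lower from compound 1 to compound 2 (within the scatter) shows that its gap to compound 1 is not beyond the scatter; only the step of a number 11.1 percentage points higher from compound 2 to compound 3 (beyond the scatter) is. The step of a number 6 percentage points higher from compound 1 to compound 3 (within the scatter) likewise stays within the scatter.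

Compound 4 `CCOC(=O)c1cn(C(c2ccccc2)c2cc3cc(Br)ccc3nc2OC)nn1` is the untested member. It differs from compound 2 in one place: ethoxycarbonyl in place of hexyl on an aromatic carbon.

Among the compounds with values here, no measured step exchanges hexyl for an ester, so the nearest guide is the step from compound 2 to compound 3, a modest rise, and the step from compound 1 to compound 2, which is within the scatter. Compound 4 is therefore expected to land near the numbers already seen, with a step of a number 3.7 percentage points higher from compound 2 to compound 4 (within the scatter) in this assay that may well stay within the scatter. The estimate for compound 4 is 6%, expected between -2% and 16%.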

Compound 4, a percentage reported as inhibition, at one concentration (the size of the read-out at that concentration, not a potency): 16.1%
The estimate for compound 4 lay 10.1 percentage points below the measured number, and the stated range ends below it.
By their numbers in this assay, from the lowest: compounds 2, 1, 3 and 4 (each within the scatter of the next, the first and the last beyond it).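

In this assay, the step of a number 13.8 percentage points higher from compound 2 to compound 4 (beyond the scatter) shows that this aromatic carbon of the five-membered aromatic ring can carry a group with no ring and still separate from hexyl, which earlier only 2-fluorophenyl had done. Ethoxycarbonyl does not separate from the aryl groups, with a number 2.7 percentage points higher from compound 3 to compound 4 (within the scatter) and a number 8.7 percentage points higher from compound 1 to compound 4 (within the scatter) as the two steps, so it cannot be ranked against 2-fluorophenyl or 4-bromophenyl. Nothing available here accounts for the step from hexyl to ethoxycarbonyl.

Going by these compounds, whether that step follows the carbonyl or the ethyl part stays open, and a carboxylic acid, an amide or a shorter alkyl chain on this carbon would help to tell them apart. Each number is also a reading at a single concentration, so the potency of these compounds remains unknown.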